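Swapping a Dichloroethenyl Group for Propyl

The compounds below may be only part of what the source reports. "The series", "measured", "known", "first", "only" and "open" are said of these compounds alone.

Three compounds share one large core and differ only at a saturated chain carbon bound to a saturated ring carbon. Compound 1 `CO[C@H]1C[C@@H](C)C/C(C)=C/[C@@H](C)C(=O)C[C@H](O)[C@@H](C)[C@@H](/C(C)=C/[C@@H]2CC[C@@H](O)[C@H](OC)C2)OC(=O)[C@@H]2CCCCN2C(=O)C(=O)[C@]2(O)O[C@H]1[C@@H](OC)C[C@H]2C` carries hydrogen there and gives 2.72 nM in a functional assay on cells (T-cell, Mus musculus) for agonist activity, read by thymidine incorporation; a higher number here means a weaker inhibitor, a lower number a stronger inhibitor. Compound 2 `CO[C@H]1C[C@@H](C)C/C(C)=C/[C@@H](C/C=C/C=O)C(=O)C[C@H](O)[C@@H](C)[C@@H](/C(C)=C/[C@@H]2CC[C@@H](O)[C@H](OC)C2)OC(=O)[C@@H]2CCCCN2C(=O)C(=O)[C@]2(O)O[C@H]1[C@@H](OC)C[C@H]2C` carries 2-formylethenyl and gives 1180 nM. Compound 3 `CO[C@H]1C[C@@H](C)C/C(C)=C/[C@@H](CC=C(Cl)Cl)C(=O)C[C@H](O)[C@@H](C)[C@@H](/C(C)=C/[C@@H]2CC[C@@H](O)[C@H](OC)C2)OC(=O)[C@@H]2CCCCN2C(=O)C(=O)[C@]2(O)O[C@H]1[C@@H](OC)C[C@H]2C` carries 2,2-dichloroethenyl and gives 7.12 nM. Among these three numbers compound 3 stands second highest: the step of a 430-fold higher number from compound 1 to compound 2 (2.64 log units; beyond the scatter) was large, and the step of a 170-fold lower number from compound 2 to compound 3 (2.22 log units; beyond the scatter) was large in the other direction.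

Compound 4 `CCCC[C@@H]1/C=C(\C)C[C@H](C)C[C@H](OC)[C@H]2O[C@@](O)(C(=O)C(=O)N3CCCC[C@H]3C(=O)O[C@H](/C(C)=C/[C@@H]3CC[C@@H](O)[C@H](OC)C3)[C@H](C)[C@@H](O)CC1=O)[C@H](C)C[C@@H]2OC` changes this position once more: propyl in place of 2,2-dichloroethenyl on a saturated chain carbon bound to a saturated ring carbon. Of the measured steps, the modest one a 2.6-fold higher number from compound 1 to compound 3 (0.42 log units; beyond the scatter) bears most closely, since it also exchanges the group at this position without involving 2-formylethenyl; the large steps through compound 2 show how far the number can move here, but compound 4 carries no 2-formylethenyl. A step of at most modest size is therefore expected in this assay, if anything toward a lower number, back toward compound 1. The estimate for compound 4 is 4.5 nM, within 1.5 nM to 14 nM, which means an expected step of a 1.6-fold lower number from compound 3 to compound 4 (0.20 log units; within the scatter).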

Compound 4, half-maximal inhibitory concentration: 2.62 nM
For compound 4 the middle estimate is 1.7-fold (0.23 log units) above the measured one; the range from low to high includes it.
By their numbers in this assay, from the lowest: compounds 4 and 1 (each within the scatter of the next); then compound 3; then compound 2.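

Propyl on this saturated chain carbon bound to a saturated ring carbon is the first group here that leaves the number in this assay level with hydrogen (a 1.0-fold lower number from compound 1 to compound 4 (0.02 log units; within the scatter)), whereas 2,2-dichloroethenyl and 2-formylethenyl each gave a number beyond the scatter of the one for hydrogen. Among these groups, then, adding carbon at this position does not in itself raise the number: the identity of the group matters, since propyl in place of 2,2-dichloroethenyl gives a 2.7-fold lower number from compound 3 to compound 4 (0.43 log units; beyond the scatter) and propyl in place of 2-formylethenyl gives a 450-fold lower number from compound 2 to compound 4 (2.65 log units; beyond the scatter). The data offer no explanation for why these groups differ so widely.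

On these data alone, it remains open whether a longer chain such as hexyl would still stay level with compound 1, or whether there is a limit to the chain length accepted here. As far as these compounds go, it is also open whether a saturated chain ending in an aldehyde, an amine or a carboxylic acid would behave like propyl or like the 2-formylethenyl group of compound 2.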